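One Ring Swapped, and Little Change Expected

The source may hold more compounds than are shown below. What is called first, only, known or untested is meant among the compounds shown, and "the series" means these compounds.

Two close relatives, compound 1 `O=C1c2ccccc2C(=O)N1CCOC(=S)N(C(=O)c1ccc([N+](=O)[O-])cc1)c1ccc(Cl)cc1` and compound 2 `O=C1c2ccccc2C(=O)N1CCOC(=S)N(C(=O)c1cccc(Cl)c1Cl)c1ccc(Cl)cc1`, have been tested in an ADME assay on MT4 cells (Homo sapiens) for cytotoxicity, read by MTT assay; on this read-out lower numbers stand for higher toxicity in this test and higher numbers for lower toxicity in this test. Compound 1 gives > 100000 nM, which is a limit of the assay and not a number. Among the measured compounds shown here, compound 2 gives 54000 nM, so it holds the only actual number so far. Compound 3 `O=C1c2ccccc2C(=O)N1CCOC(=S)N(C(=O)c1ccc(Cl)c([N+](=O)[O-])c1)c1ccc(Cl)cc1` has not yet been measured, and it differs from compound 2 in a single group: 4-chloro-3-nitrophenyl in place of 2,3-dichlorophenyl on a carbonyl carbon. Here 4-chloro-3-nitrophenyl takes the place of 2,3-dichlorophenyl on a carbonyl carbon. For the measured compounds named here, only one measured step bears on this, a change at the same place: an at least 1.8-fold lower number from compound 1 to compound 2 (0.26 log units; that floor lies within the scatter). That step does not clearly exceed the scatter, so no shift beyond the scatter is expected in this assay. The expected step is a 1.1-fold higher number from compound 2 to compound 3 (0.05 log units; within the scatter). For compound 3 the estimate is 60000 nM, with an expected range from 25000 nM to 140000 nM.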

Compound 3, half-maximal cytotoxic concentration: 48000 nM
Compound 3: the middle estimate sits 1.3-fold (0.10 log units) above what was measured; low and high end bracket the measured number.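

At this place on a carbonyl carbon, in this assay, the newly measured swap gives a 1.1-fold lower number from compound 2 to compound 3 (0.05 log units; within the scatter), so 2,3-dichlorophenyl and 4-chloro-3-nitrophenyl cannot be told apart here, although only the entering group carries hydrogen-bond acceptors. Among the compounds shown here, the comparison with 4-nitrophenyl now yields the first step beyond the scatter at this place, an at least 2.0-fold lower number from compound 1 to compound 3 (0.31 log units; beyond the scatter). Compound 1 has a limit and not a number, so that step is only a floor: the limit of > 100000 nM in this assay, at which 1 of the 3 values shown sits.

All the groups shown at this place are substituted phenyl rings bearing chlorine, nitro or both. As far as these compounds go, it remains open how far the number would move with a phenyl ring bearing an amine or a carboxylic acid, or with an open alkyl chain in place of the ring.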